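The source may report more compounds than this note shows. Statements on the series, on what has been measured and on what is new or still open speak of the compounds shown alone.

Measured so far:
compound 1, `C=C1C=CCO[C@@H]1n1cc(C)c(O)nc1=O`, 504000 nM
compound 2, `O=C(Nc1ccn([C@H]2OCC=CC2=O)c(=O)n1)c1ccccc1`, 46000 nM

Both compounds were tested in a functional assay on CCRF-CEM cells (Homo sapiens), with a stated time of 3 days (on this read-out higher numbers stand for weaker inhibition and lower numbers for stronger inhibition), a read-out of how strongly a compound holds back the growth of a leukaemia cell line over the stated period. In this assay compound 1 gives 504000 nM and compound 2 gives 46000 nM. Compound 2 therefore stands lowest of the two numbers, and its nearest neighbour, compound 1, sits higher by a gap that lies beyond the usual scatter of repeated measurements. Both numbers are high on this scale, so neither compound is a strong inhibitor.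

Compound 3, `C=C1C=CCO[C@@H]1n1ccc(NC(=O)c2ccccc2)nc1=O`, has not yet been measured. It differs from compound 2 in one place: a group of 7 heavy atoms (6 carbon, 1 oxygen; one six-membered non-aromatic ring with 1 hetero atom) in place of a group of 7 heavy atoms (5 carbon, 2 oxygen; one six-membered non-aromatic ring with 1 hetero atom), on an aromatic nitrogen

Going by the values given here, the two measured compounds differ from each other in more than one place, so no single step between them can be read off, and no step of the same kind as the one from compound 2 to compound 3 has been measured. The expectation for compound 3 is therefore wide. Because compound 2 gives 46000 nM and the ring that enters resembles the ring found in compound 1, which gives 504000 nM, a step of a 2.2-fold higher number from compound 2 to compound 3 (0.34 log units; beyond the scatter) towards a somewhat higher number is expected, though a change within the scatter would not be surprising. Compound 3 is estimated to give 100000 nM in this assay, with a range from 20000 nM to 500000 nM.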

Compound 3, half-maximal inhibitory concentration: 432000 nM
Beside the measured number, compound 3's estimate is 4.3-fold (0.64 log units) below it; measured number inside the range.
By their numbers in this assay, from the lowest: compound 2; then compounds 3 and 1 (each within the scatter of the next).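

In this assay, going by these compounds alone, the change on the aromatic nitrogen brings a 9.4-fold higher number from compound 2 to compound 3 (0.97 log units; beyond the scatter) and gives the first step that can be read on its own. Everything else in the two molecules stays the same, so this position clearly matters: the ring that leaves, with 5 carbon and 2 oxygen atoms, goes with stronger inhibition than the ring that enters, with 6 carbon and 1 oxygen atoms, even though both rings have six members, 7 heavy atoms, 2 double bonds outside aromatic rings and 1 defined stereocentre. The step therefore goes with a swap of one oxygen for one carbon and the loss of one hydrogen-bond acceptor, but nothing available explains why the number rises.

Going by these compounds, this is a single step on a single background, so it remains open whether the same ring exchange would have a similar effect on a molecule carrying a plain amine in place of the amide. On these data alone, it is also open how a simple ethyl chain or a longer chain on the aromatic nitrogen would compare with either ring.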